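Swapping Iodine for Bromine on a Fused Indole Core

The compounds below may be only part of what the source reports. "The series", "measured", "known", "first", "only" and "open" are said of these compounds alone.

Four close relatives share one core: a thiol-bearing acrylic acid attached to a bicyclic aromatic system, with a single halogen on the six-membered carbon ring. Compound 1, `O=C(O)/C(S)=C/c1c[nH]c2cc(Br)ccc12`, carries bromine; compound 2, `O=C(O)/C(S)=C/c1c[nH]c2cc(I)ccc12`, carries iodine at the same place. In an assay on isolated protein for inhibition of Calpain-1 catalytic subunit (Sus scrofa), read by FRET (a higher number here means a weaker inhibitor, a lower number a stronger inhibitor), compound 1 gives 7 nM, while compound 2 gives 170 nM. The change from compound 2 to compound 1 is bromo in place of iodo on an aromatic carbon, and it produced a 24-fold lower number from compound 2 to compound 1 (1.39 log units; beyond the scatter).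

Compound 3, `O=C(O)/C(S)=C/c1c[nH]c2ccc(I)cc12`, also carries iodine, but its core and that of compound 2 differ in how the same atoms are joined; that difference between the two cores is not broken down here. In this assay compound 3 gives 100 nM, which stands within the usual scatter of the number for compound 2.

Compound 4, `O=C(O)/C(S)=C/c1c[nH]c2ccc(Br)cc12`, has not yet been measured. It differs from compound 3 by bromo in place of iodo on an aromatic carbon, the same change as that from compound 2 to compound 1, at a place described in identical words. Because the earlier change gave a 24-fold lower number from compound 2 to compound 1 (1.39 log units; beyond the scatter), a drop is expected here too, though with a core that is not the same, the size is uncertain. The expected step from compound 3 to compound 4 is a 5.0-fold lower number from compound 3 to compound 4 (0.70 log units; beyond the scatter). Compound 4 is estimated to give 20 nM in this assay, within a range from 5 nM to 80 nM.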

Compound 4, half-maximal inhibitory concentration: 6 nM
For compound 4 the middle estimate is 3.3-fold (0.52 log units) above the measured one; low and high end bracket the measured number.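

In this assay, bromo in place of iodo on an aromatic carbon gave a 17-fold lower number from compound 3 to compound 4 (1.22 log units; beyond the scatter), so the change lowers the number on the core of compound 3 as well as on the core of compound 1. Set side by side, the two steps do not differ in size, which means that in this series the change carried from one core to the other with its effect intact: the same change on two cores in this assay, a 24-fold lower number (1.39 log units; beyond the scatter) from compound 2 to compound 1 and a 17-fold lower number (1.22 log units; beyond the scatter) from compound 3 to compound 4, 1.5-fold (0.16 log units) apart, within the scatter of two such steps

This agreement rests on just two pairs of compounds, so it shows that the step held on these two cores and does not establish a rule for any further core, nor does it reveal why bromo gives the lower number.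

The compounds shown leave open how other groups in that place, such as chloro, fluoro or methoxy, would compare with bromo and iodo. On these data alone, every compound here also keeps the thiol and the carboxylic acid, so it remains open whether the same step would appear if a hydroxyl replaced the thiol or an amide replaced the carboxylic acid.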